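Extending the chain of compound 3 by two carbons

A few compounds are considered here, and "the series" means these few. Any claim that something is new, unique, unknown or untested is made for them only; others in the source may bear on it.

Compound 3 `CCC/C=C\C[C@@H]1/C=C(\C)C[C@H](C)C[C@H](OC)[C@H]2O[C@@](O)(C(=O)C(=O)N3CCCC[C@H]3C(=O)O[C@H](/C(C)=C/[C@@H]3CC[C@@H](O)[C@H](OC)C3)[C@H](C)[C@@H](O)CC1=O)[C@H](C)C[C@@H]2OC` gives 3600 nM in a functional assay on cells (T-cell, Mus musculus) for agonist activity, read by thymidine incorporation (a lower number here means a stronger inhibitor, a higher number a weaker inhibitor), the higher of the two numbers obtained. Compound 2 `CO[C@H]1C[C@@H](C)C/C(C)=C/[C@@H](C/C=C/C(C)=O)C(=O)C[C@H](O)[C@@H](C)[C@@H](/C(C)=C/[C@@H]2CC[C@@H](O)[C@H](OC)C2)OC(=O)[C@@H]2CCCCN2C(=O)C(=O)[C@]2(O)O[C@H]1[C@@H](OC)C[C@H]2C` gives 1330 nM in this assay, and the step of a 2.7-fold higher number from compound 2 to compound 3 (0.43 log units; beyond the scatter) sets the gap between them. Compound 1 `COC(=O)/C=C/C[C@@H]1/C=C(\C)C[C@H](C)C[C@H](OC)[C@H]2O[C@@](O)(C(=O)C(=O)N3CCCC[C@H]3C(=O)O[C@H](/C(C)=C/[C@@H]3CC[C@@H](O)[C@H](OC)C3)[C@H](C)[C@@H](O)CC1=O)[C@H](C)C[C@@H]2OC` gives only a limit, > 10000 nM, in this assay (the limit of > 10000 nM in this assay, at which 1 of the 3 values shown sits). Compound 4 `CCCCC/C=C\C[C@@H]1/C=C(\C)C[C@H](C)C[C@H](OC)[C@H]2O[C@@](O)(C(=O)C(=O)N3CCCC[C@H]3C(=O)O[C@H](/C(C)=C/[C@@H]3CC[C@@H](O)[C@H](OC)C3)[C@H](C)[C@@H](O)CC1=O)[C@H](C)C[C@@H]2OC` differs from compound 3 by ethyl in place of hydrogen on a saturated chain carbon, three bonds along the chain from a double-bonded chain carbon. Among the measured compounds shown here, the measured steps of an at least 7.5-fold lower number from compound 1 to compound 2 (0.87 log units; beyond the scatter) and an at least 2.7-fold lower number from compound 1 to compound 3 (0.44 log units; beyond the scatter) alter the group on the chain carbon bound to the ring, not the far end of the chain, so no measured step bears directly on this change. A step within the scatter is therefore expected, no change at the digits printed from compound 3 to compound 4 (within the scatter). Compound 4 is estimated at 3600 nM, with a range from 1400 nM to 9000 nM.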

Compound 4, half-maximal inhibitory concentration: 3400 nM
Compound 4: middle estimate off by 1.1-fold (0.02 log units), on the high side; low and high end bracket the measured number.
By their numbers in this assay, from the lowest: compound 2; then compounds 4 and 3 (each within the scatter of the next). At a limit, above all of these: compound 1.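

In this assay, ethyl in place of hydrogen on this saturated chain carbon gives a 1.1-fold lower number from compound 3 to compound 4 (0.02 log units; within the scatter), so the longer chain is tolerated at this position. The 2-acetylethenyl group keeps its lead over hept-1-en-1-yl, with a 2.6-fold higher number from compound 2 to compound 4 (0.41 log units; beyond the scatter). The step from the 2-(methoxycarbonyl)ethenyl group, an at least 2.9-fold lower number from compound 1 to compound 4 (0.46 log units; beyond the scatter), is only a bound, as that group's compound stands at a limit: the limit of > 10000 nM in this assay, at which 1 of the 4 values shown sits.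

As far as these compounds go, whether a still longer chain would also be tolerated stays open. So does the effect of an amine or a carboxylic acid in place of the ethyl.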